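Enantiomer of compound 2: tolerance on Vero cells

The compounds below may be only part of what the source reports. "The series", "measured", "known", "first", "only" and "open" are said of these compounds alone.

Compound 2 `COc1ccc(-n2c(S[C@H](C)C(=O)Nc3ccc(C)cc3Cl)nc3ccccc32)cc1` has been run in an ADME assay on Vero cells (Chlorocebus sabaeus) for cytotoxicity, read by MTT assay, with a stated time of 24 h; a lower number here means that less compound is tolerated, a higher number that more compound is tolerated. Compound 2 gives > 75000 nM, which is a limit of the assay and not a number. Compound 1 `Cc1ccc(NC(=O)C(C)Sc2nc3ccccc3n2Cc2ccccc2)c(Cl)c1` likewise gives > 75000 nM, again a limit. Among the compounds with values here, compound 2 thus stands at the limit of > 75000 nM in this assay, at which 2 of the 2 values shown sit; no numerical reading exists for it, and no step between measured compounds can be computed from this pair.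

Compound 3 `COc1ccc(-n2c(S[C@@H](C)C(=O)Nc3ccc(C)cc3Cl)nc3ccccc32)cc1` is not yet measured. It relates to compound 2 as follows: the two compounds have the same atoms and bonds and differ only in configuration as drawn: 1 of 1 stereo elements differ; a stereocentre at a saturated chain carbon is drawn R in compound 2 and S in compound 3. Nothing in the measured pair points to a direction, and in this assay the step that the limit leaves unreadable from compound 2 to compound 3 is expected to stay within the scatter. For compound 3 the expected reading is 100000 nM, with a range from 50000 nM to 300000 nM, and most likely the result is again reported only as a limit.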

Compound 3, half-maximal cytotoxic concentration: > 75000 nM
Compound 3: no number, only a limit; the forecaster's own chance of this, stated with the estimate: 90%; the middle value lies beyond the limit too.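

Within the data shown here, compound 2 and compound 3 both sit at a limit of the assay in this assay, not at a number, so no step between them can be read. The compounds shown leave open whether the two drawn configurations differ in tolerated concentration beyond that limit.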